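The source may report more compounds than this note shows. Statements on the series, on what has been measured and on what is new or still open speak of the compounds shown alone.

Compound 1 `C=Cc1nc2ccccc2[se]1` carries a vinyl group on an aromatic carbon of its core, and compound 2 `C#Cc1nc2ccccc2[se]1` differs from it by ethynyl in place of vinyl on an aromatic carbon. In a functional assay on NCI-H522 cells (Homo sapiens) for cytotoxicity, with a stated time of 3 days (on this read-out higher numbers stand for weaker inhibition and lower numbers for stronger inhibition), compound 1 gives 12200 nM, while in this assay compound 2 gives 2170 nM, which amounts to a 5.6-fold lower number from compound 1 to compound 2 (0.75 log units; beyond the scatter). Compound 3 `C=Cc1csc(Br)n1` rests on a different core; the difference between the two cores is not broken down here. In this assay compound 3 reaches only a limit of the assay, > 40000 nM, and the limit of > 40000 nM in this assay, at which 1 of the 3 values shown sits, describes where that value sits. Compound 4 `C#Cc1csc(Br)n1` has not yet been measured; it differs from compound 3 by ethynyl in place of vinyl on an aromatic carbon. This is the same kind of change as that between compound 1 and compound 2, but the surroundings differ: in compound 1 the place is next to the ring nitrogen and next to the ring selenium of a fused system of two rings, whereas in compound 3 it is next to the ring nitrogen, two ring bonds from the ring sulfur and two ring bonds from the ring atom that bears a bromo group. For the measured compounds named here, for compound 4 in this assay a step of an at least 2.0-fold lower number from compound 3 to compound 4 (0.30 log units; that floor lies within the scatter) is expected, resting on the single measured example of this change, a 5.6-fold lower number from compound 1 to compound 2 (0.75 log units; beyond the scatter), with wide uncertainty since compound 3 is known only as a limit. The estimate for compound 4 in this assay is 20000 nM, with a lower end of 5000 nM and an upper end of 80000 nM.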

Compound 4, half-maximal inhibitory concentration: > 40000 nM
Compound 4: only a limit was reported; the forecaster's own chance of this, stated with the estimate: 40%; middle value at least 2.0-fold (0.30 log units) from the limit.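

In this assay compound 3 and compound 4 both reach only a limit of the assay, so no step between them can be read: the limit of > 40000 nM in this assay, at which 2 of the 4 values shown sit.

The compounds shown leave open whether ethynyl in place of vinyl changes the number at all on the core of compound 3, as it does on the core of compound 1.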